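Notes on the aryl-position change toward compound 4

The source may hold more compounds than are shown below. What is called first, only, known or untested is meant among the compounds shown, and "the series" means these compounds.

The three measured compounds share one core and differ only in the group on an aromatic carbon. In an assay on CHO cells for antagonist activity at transient receptor potential cation channel subfamily V member 1 (Homo sapiens), read by FLIPR (a lower number here means a stronger inhibitor, a higher number a weaker inhibitor), compound 1 `CC(C(=O)NCc1ccc(C(F)(F)F)nc1-c1ccccc1)c1ccc(NS(C)(=O)=O)c(F)c1` gives 6.4 nM. Compound 2 `CC(C(=O)NCc1ccc(C(F)(F)F)nc1-c1ccc(N(C)C)cc1)c1ccc(NS(C)(=O)=O)c(F)c1` gives 3.2 nM in this assay, and compound 3 `CC(C(=O)NCc1ccc(C(F)(F)F)nc1-c1ccc(Cl)c(Cl)c1)c1ccc(NS(C)(=O)=O)c(F)c1` gives 0.9 nM. Compound 2 thus stands second highest of the three numbers: its gap to compound 1, a 2.0-fold lower number from compound 1 to compound 2 (0.30 log units; within the scatter), is within the scatter, while a 3.6-fold lower number from compound 2 to compound 3 (0.55 log units; beyond the scatter) and a 7.1-fold lower number from compound 1 to compound 3 (0.85 log units; beyond the scatter) are beyond it.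

Compound 4 `CC(C(=O)NCc1ccc(C(F)(F)F)nc1CCc1ccc(F)cc1)c1ccc(NS(C)(=O)=O)c(F)c1` is not yet measured. The change from compound 2 is 2-(4-fluorophenyl)ethyl in place of 4-(dimethylamino)phenyl on an aromatic carbon. Going by the values given here, no measured step exchanges the 4-(dimethylamino)phenyl for a 2-(4-fluorophenyl)ethyl chain; the measured steps only swap substituents on an aromatic ring standing on that carbon, with the dimethylamino swap within the scatter and the 3,4-dichlorophenyl swaps modest. The change to compound 4 is therefore not anchored by any measured step, and a step in either direction remains possible. Compound 4 is expected to give about 12 nM in this assay, within 3 nM to 50 nM, which means an estimated step of a 3.8-fold higher number from compound 2 to compound 4 (0.57 log units; beyond the scatter).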

Compound 4, inhibition constant: 1.8 nM
Compound 4: the middle estimate sits 6.7-fold (0.82 log units) above what was measured, and the stated range ends above it.
By their numbers in this assay, from the lowest: compounds 3, 4, 2 and 1 (each within the scatter of the next, the first and the last beyond it).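

In this assay, the aromatic carbon next to the ring nitrogen accepts more than a phenyl ring standing directly on it: with 2-(4-fluorophenyl)ethyl in that place, a 1.8-fold lower number from compound 2 to compound 4 (0.25 log units; within the scatter) and a 2.0-fold higher number from compound 3 to compound 4 (0.30 log units; within the scatter) leave compound 4 level with both substituted phenyl compounds. Against the plain phenyl the same group gives a real gain, a 3.6-fold lower number from compound 1 to compound 4 (0.55 log units; beyond the scatter), so a change in how the aromatic ring is attached, and not only in the substituents on that ring, can separate a compound from compound 1. Nothing at hand accounts for this result.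

A 2-phenylethyl group without the fluorine would separate the share of the chain from that of the fluorine. Going by these compounds, how a longer chain such as 3-phenylpropyl, or an amine on this carbon, would read remains open.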